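Methoxy in place of hydrogen on the anilide ring

The source may report more compounds than this note shows. Statements on the series, on what has been measured and on what is new or still open speak of the compounds shown alone.

Compound 2 `O=C(CSC(=S)N[C@H]1CCOC1=O)Nc1ccccc1` sits at the limit of a functional assay on SMMC-7721 cells (Homo sapiens) for cytotoxicity, read by MTT assay, with a stated time of 72 h (a lower number here means a stronger inhibitor, a higher number a weaker inhibitor), rather than at a number. In this assay compound 2 gives > 128000 nM, which is a limit. The bromo analogue is compound 1 `O=C(CSC(=S)N[C@H]1CCOC1=O)Nc1ccc(Br)cc1`; in this assay compound 1 gives 28300 nM. Among the compounds with values here, the one measured step here is an at least 4.5-fold higher number from compound 1 to compound 2 (0.65 log units; beyond the scatter); its size is bounded only by the limit of > 128000 nM in this assay, at which 1 of the 2 values shown sits. Compound 3 `COc1ccc(NC(=O)CSC(=S)N[C@H]2CCOC2=O)cc1` differs from compound 2 by methoxy in place of hydrogen on an aromatic carbon, on an aromatic carbon of a six-membered aromatic ring of carbon only, para to a large group. Within the data shown here, the bromo step bears on it only in the sense that the same position is occupied, and bromo and methoxy are different groups; no measured step tells what methoxy does there. A modest lowering of the number from compound 2 is expected, an at least 1.2-fold lower number from compound 2 to compound 3 (0.10 log units; that floor lies within the scatter), with a fair chance that only a limit is again reported. Compound 3 is therefore estimated at 100000 nM, in the range 30000 nM to 400000 nM.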

Compound 3, half-maximal inhibitory concentration: > 128000 nM
Compound 3: no number, only a limit; the forecaster's own chance of this, stated with the estimate: 50%; middle value at least 1.2-fold (0.10 log units) away from the limit.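

In this assay compound 3 gives > 128000 nM, which is a limit, so methoxy on this aromatic carbon, para to a large group, yields no number, and the step from hydrogen to methoxy cannot be read. Methoxy does not match bromo at this position, with an at least 4.5-fold higher number from compound 1 to compound 3 (0.65 log units; beyond the scatter). Compound 1 therefore remains the only compound shown with a number, and the comparison is bounded by: the limit of > 128000 nM in this assay, at which 2 of the 3 values shown sit.

Going by these compounds, whether methoxy changes the read-out at all relative to hydrogen remains open, as does how far either compound lies from compound 1. On these data alone, it is also open whether the number seen with bromo is specific to that group or would also appear with chloro, an amine or a carboxylic acid on the same carbon.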